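This account rests on a few compounds, and the source may have more. Where it says the series, first, only, none or still open, it means among the compounds named here.

Measured so far in a functional assay on HL-60 cells (Homo sapiens) for inhibition; a higher number here means a weaker inhibitor, a lower number a stronger inhibitor:
- Compound 1 `COc1cc(/C=C/c2ccc3c(ccn3S(=O)(=O)c3ccccc3)c2)cc(OC)c1OC`: > 5000 nM
- Compound 2 `COc1cc(/C=C\c2ccc3c(ccn3S(=O)(=O)c3ccccc3)c2)cc(OC)c1OC`: > 5000 nM

Compound 1 stands at > 5000 nM, which is a limit of the assay and not a number. Compound 2 gives > 5000 nM, which is also a limit. Going by the values given here, the one measured step is a step that the two limits leave unreadable from compound 1 to compound 2, and the fact that compounds 1 and 2 differ only in the configuration as drawn is all that separates the pair, so it gives no size to carry forward.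

Compound 3 `COc1cc(/C=C/c2ccc3[nH]ccc3c2)cc(OC)c1OC` departs from compound 1 by hydrogen in place of phenylsulfonyl on an aromatic nitrogen. Put simply, hydrogen replaces phenylsulfonyl on an aromatic nitrogen. Among the compounds with values here, no measured step involves this change, and the limit of > 5000 nM in this assay, at which 2 of the 2 values shown sit, provides no exact starting number. Any readable result in this assay would therefore have to show stronger inhibition than compound 1, but the size cannot be derived from the data. A cautious expectation is an at least 1.6-fold lower number from compound 1 to compound 3 (0.22 log units; that floor lies within the scatter), towards stronger inhibition. For compound 3, the estimated value is 3000 nM, with an expected range from 300 nM to 10000 nM. A further result reported only as a limit would not be surprising.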

Compound 3, half-maximal inhibitory concentration: 380 nM
Compound 3: the middle estimate sits 7.9-fold (0.90 log units) above what was measured; the measured number falls inside the stated range.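

In this assay, going by these compounds alone, hydrogen in place of phenylsulfonyl on an aromatic nitrogen gives an at least 13-fold lower number from compound 1 to compound 3 (1.11 log units; beyond the scatter), the first step here with a readable size and one well beyond the usual scatter. Compound 1 gives > 5000 nM, which is a limit of the assay and not a number. The step is therefore a floor and not an exact size, because its starting point is such a limit: the limit of > 5000 nM in this assay, at which 2 of the 3 values shown sit.

The step between compound 1 and compound 2 cannot be read, so the effect of the double-bond configuration stays unknown, and the compounds shown do not say whether it would matter once hydrogen sits on the aromatic nitrogen. The whole phenylsulfonyl group leaves in one change, so the compounds shown cannot separate the part played by its six-membered ring from that of the sulfonyl, and a methyl or an acetyl group on the same nitrogen would show whether inhibition needs the hydrogen itself or only the absence of phenylsulfonyl.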